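The source may report more compounds than this note shows. Statements on the series, on what has been measured and on what is new or still open speak of the compounds shown alone.

Compound 1 `O=C1/C(=C/c2ccccc2F)CN(S(=O)(=O)c2ccc(F)cc2)C/C1=C\c1ccccc1F`: 8370 nM
Compound 2 `CC(=O)Nc1ccc(S(=O)(=O)N2C/C(=C\c3ccccc3F)C(=O)/C(=C/c3ccccc3F)C2)cc1`: 7490 nM
Compound 3 `CC(=O)Nc1ccc(S(=O)(=O)N2C/C(=C\c3ccc(C#N)cc3)C(=O)/C(=C/c3ccc(C#N)cc3)C2)cc1`: 7120 nM

All three values come from a functional assay on SMMC-7721 cells (Homo sapiens) for cytotoxicity, read by MTT assay, with a stated time of 24 h (on this read-out lower numbers stand for stronger inhibition and higher numbers for weaker inhibition), and compound 2 lies within the scatter of both other compounds. Compound 4 `COc1cc(/C=C2\CN(S(=O)(=O)c3ccc(NC(C)=O)cc3)C/C(=C\c3ccccc3F)C2=O)cc(OC)c1` is still unmeasured, and its difference from compound 2 is 3,5-dimethoxyphenyl in place of 2-fluorophenyl on a double-bonded chain carbon bound to a double-bonded ring carbon. Among the measured compounds shown here, the only measured step, a 1.1-fold lower number from compound 1 to compound 2 (0.05 log units; within the scatter), is a different exchange, so it bears on this change only indirectly. For the measured compounds named here, no measured step makes this exchange, so the expectation is weakly grounded. The expected change is a 1.2-fold lower number from compound 2 to compound 4 (0.06 log units; within the scatter), with no shift beyond the scatter anticipated. Compound 4 is estimated at 6500 nM, with an expected range of 2500 nM to 14000 nM.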

Compound 4, half-maximal inhibitory concentration: 5210 nM
For compound 4 the middle estimate is 1.2-fold (0.10 log units) above the measured one; low and high end bracket the measured number.
By their numbers in this assay, from the lowest: compounds 4, 3, 2 and 1 (each within the scatter of the next).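

In this assay, among the compounds shown here, the step of a 1.4-fold lower number from compound 2 to compound 4 (0.16 log units; within the scatter) is the first measured exchange at this position and stays within the scatter. The position therefore tolerates 3,5-dimethoxyphenyl, a larger group that carries hydrogen-bond acceptors, in place of 2-fluorophenyl without a shift beyond the scatter. No supporting data bear on this result.

On these data alone, whether an amine or a carboxylic acid on the aromatic ring at this position would move the number beyond the scatter remains open. So does whether an exchange of a simple phenyl for a longer chain here would leave the number unchanged.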